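This account rests on a few compounds, and the source may have more. Where it says the series, first, only, none or still open, it means among the compounds named here.

Measured in an assay on HEK293 cells for inhibition of acid ceramidase (Homo sapiens), read by fluorescence, with stated times of 30 min and 1 h; a higher number here means a weaker inhibitor, a lower number a stronger inhibitor:

Compound 1 `CCCCCCNC(=O)Nc1nc2ccccc2s1` gives > 10000 nM, which is a limit of the assay.

Compound 2 `COc1nc2ccccc2n1C(=O)NCCCCc1ccccc1` gives 13.9 nM.

Compound 3 `O=C(NCCCCc1ccccc1)Nc1nc2ccccc2[nH]1` gives > 10000 nM, which is a limit of the assay.

Going by the values given here, compound 2 thus holds the only number in this assay; the other two values sit at the limit of > 10000 nM in this assay, at which 2 of the 3 values shown sit. Not yet measured is compound 4 `Cc1nc2ccccc2n1C(=O)NCCCCc1ccccc1`. From compound 2 to compound 4 the change is methyl in place of methoxy on an aromatic carbon. Among the compounds with values here, no measured pair differs in this one place, so the size of the step rests on the change itself. The expected step from compound 2 to compound 4 is a 2.9-fold higher number from compound 2 to compound 4 (0.46 log units; beyond the scatter), a modest loss, near the edge of the scatter. Compound 4 is estimated at 40 nM, in the range 10 nM to 200 nM.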

Compound 4, half-maximal inhibitory concentration: 1 nM
Compound 4: middle estimate off by 40-fold (1.60 log units), on the high side; the whole stated range lies above it.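

Methyl in place of methoxy gives a 14-fold lower number from compound 2 to compound 4 (1.14 log units; beyond the scatter), the first step read in this series, so the group on this aromatic carbon, between two ring nitrogen atoms, bears strongly on the number. Methoxy is thus not needed here, and the oxygen can leave without loss. Nothing shown gives a cause for this step.

Open, from the compounds shown here alone, is how an ethyl, a chlorine or an amine at this place compares with methyl and methoxy. Also open, going by these compounds, is whether the step holds with a different chain on the urea-like carbonyl.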